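The source may report more compounds than this note shows. Statements on the series, on what has been measured and on what is new or still open speak of the compounds shown alone.

In a functional assay on WM 266-4 cells (Homo sapiens) for antiproliferative activity, read by MTT assay, with a stated time of 24 h (a lower number here means a stronger inhibitor of growth, a higher number a weaker inhibitor of growth), compound 1 `FC(F)(F)c1ccc(C2CC(c3ccc4c(c3)OCCO4)=NN2c2ccccc2)cc1` is reported only as a limit, > 100000 nM. For the measured compounds named here, compound 2 `Fc1ccc(C2CC(c3ccc4c(c3)OCCO4)=NN2c2ccccc2)cc1` gives 6050 nM, the only actual number so far. Compound 3 `Clc1ccc(C2CC(c3ccc4c(c3)OCCO4)=NN2c2ccccc2)cc1` differs from it by chloro in place of fluoro on an aromatic carbon, with chloro in place of fluoro on an aromatic carbon, para to a large group. Going by the values given here, the one measured step at this place, an at least 16-fold lower number from compound 1 to compound 2 (1.21 log units; beyond the scatter), is large, so this position clearly matters, though that step starts from a limit and involves a different group. A modest 1.5-fold higher number from compound 2 to compound 3 (0.17 log units; within the scatter) is therefore expected, towards weaker growth inhibition. Compound 3 is estimated at 9000 nM, with a range of 3000 nM to 30000 nM.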

Compound 3, concentration for 50% growth inhibition: 38600 nM
Estimate against measurement, compound 3: 4.3-fold (0.63 log units) below; measured number above the stated range.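

In this assay, this position separates even chloro from fluoro, with a 6.4-fold higher number from compound 2 to compound 3 (0.80 log units; beyond the scatter), so the change is not a neutral exchange of one atom for another. Chloro in place of trifluoromethyl gives an at least 2.5-fold lower number from compound 1 to compound 3 (0.41 log units; beyond the scatter), which places the 4-chlorophenyl compound between the other two and puts the 4-fluorophenyl compound at the strong end. Compound 1 is reported only as a limit, so this last step gives a minimum and not a size: the limit of > 100000 nM in this assay, at which 1 of the 3 values shown sits.

On these data alone, whether this order extends to an amine, a methoxy group or a carboxylic acid at this place remains open. So does the effect of leaving the ring with hydrogen alone there.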